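Fluoro on the pyridin-2-yl ring: expected metabolic stability

The compounds below may be only part of what the source reports. "The series", "measured", "known", "first", "only" and "open" are said of these compounds alone.

Measured compounds:
compound 1 `COc1cccnc1Nc1cc2[nH]c(-c3cccc(C(F)(F)F)c3)nc2cn1` — 69%
compound 2 `Fc1ccc(-c2nc3cnc(Nc4ccccn4)cc3[nH]2)cc1F` — 91%
compound 3 `Fc1ccc(-c2nc3cnc(Nc4ccc(C(F)(F)F)cn4)cc3[nH]2)cc1F` — 88%

In an ADME assay on microsomes from liver (Homo sapiens) for metabolic stability, read by LC-MS, with a stated time of 30 min, tested at 0.1 uM (on this read-out higher numbers stand for a more stable compound and lower numbers for a less stable compound), compound 2 gives 91%, the highest of the three numbers. Compound 3 lies closest to it, and compound 1 lies furthest away, with a gap beyond the scatter. The step of a number 3 percentage points lower from compound 2 to compound 3 (within the scatter) shows that a trifluoromethyl in place of hydrogen on an aromatic carbon of that ring left this assay unchanged within the scatter.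

Compound 4 `Fc1ccnc(Nc2cc3[nH]c(-c4ccc(F)c(F)c4)nc3cn2)c1` differs from compound 2 by fluoro in place of hydrogen on an aromatic carbon; the same change, cut one bond further out, reads pyridin-2-yl to 4-fluoropyridin-2-yl, the new group sitting meta to a large group and opposite the ring nitrogen. Going by the values given here, the only measured step that bears on it is the one from compound 2 to compound 3, a substitution on the same ring that stayed within the scatter. On that basis no step beyond the scatter in this assay is expected for compound 4, and the expected step is a number 3 percentage points lower from compound 2 to compound 4 (within the scatter). The estimate for compound 4 in this assay is 88%, with a range from 78% to 96%.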

Compound 4, percent of the compound remaining: 92%
Beside the measured number, compound 4's estimate is 4 percentage points below it; low and high end bracket the measured number.
By their numbers in this assay, from the lowest: compound 1; then compounds 3, 2 and 4 (each within the scatter of the next).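

Placing fluoro on an aromatic carbon opposite the ring nitrogen gives, in this assay, a number 1 percentage points higher from compound 2 to compound 4 (within the scatter), so this position of the pyridin-2-yl ring now has a measured step of its own rather than a reading borrowed from another substitution. Set beside a number 3 percentage points lower from compound 2 to compound 3 (within the scatter), which carries trifluoromethyl instead, it means that both single changes shown on this ring, one of a single fluorine and one of a trifluoromethyl group, stay within the scatter, and neither compound 3 nor compound 4 goes against this. The data shown offer no measurement that explains why the read-out holds at this position.

On these data alone, it remains open whether a different group opposite the ring nitrogen, such as an amine, a nitrile or a carboxylic acid, would also stay within the scatter in this assay. Going by these compounds alone, also open is whether the same fluoro would read the same on a less stable parent such as compound 1, at 69%, which differs from compound 2 in more than one place and so gives no step here.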